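This account rests on a few compounds, and the source may have more. Where it says the series, first, only, none or still open, it means among the compounds named here.

Working notes on the series. Compound 1, `COC(=O)CCCNC(=O)CN1CN(c2ccccc2)C2(CCN(C(=O)c3ccc(C4CCCCC4)cc3)CC2)C1=O`, is the anchor of the set: in an assay on HEK293 cells for displacement of a labelled ligand from NPC1-like intracellular cholesterol transporter 1 (Homo sapiens) (on this read-out lower numbers stand for stronger inhibition and higher numbers for weaker inhibition), compound 1 gives 2500 nM, the lowest of the two numbers recorded so far. Among the compounds with values here, the only other measured member is compound 2, `CCOC(=O)C1CCCN(C(=O)CN2CN(c3ccccc3)C3(CCN(C(=O)c4ccc(C(C)(C)C)cc4)CC3)C2=O)C1`, which in this assay gives 8200 nM; compound 2 differs from compound 1 in two places at once, so nothing is recorded as a single step between them, and their two values show only that compound 2 sits clearly weaker than compound 1, beyond the scatter.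

Compound 3, `CC1CCCN(C(=O)CN2CN(c3ccccc3)C3(CCN(C(=O)c4ccc(C5CCCCC5)cc4)CC3)C2=O)C1`, is not yet measured in this assay. It departs from compound 1 at a single place: 3-methylpiperidin-1-yl in place of (3-(methoxycarbonyl)propyl)amino on a carbonyl carbon. The amide hydrogen and both acceptors of the leaving group are gone, and a six-membered non-aromatic ring takes their place on the carbonyl carbon. With no measured step of this kind in the set, the expectation for this assay is a step from compound 1 to compound 3 of a 1.4-fold higher number from compound 1 to compound 3 (0.15 log units; within the scatter), at the edge of the scatter and, if anything, toward a higher number. Compound 3 is thus estimated at 3500 nM, within a range of 1200 nM to 10000 nM.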

Compound 3, half-maximal inhibitory concentration: 3600 nM
For compound 3 the middle estimate is 1.0-fold (0.01 log units) below the measured one, and the stated range covers the measured number.
By their numbers in this assay, from the lowest: compounds 1 and 3 (each within the scatter of the next); then compound 2.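

In this assay, within the data shown here, the change on the carbonyl carbon whose other neighbour is a saturated chain carbon, 3-methylpiperidin-1-yl in place of (3-(methoxycarbonyl)propyl)amino, reads as a 1.4-fold higher number from compound 1 to compound 3 (0.16 log units; within the scatter), and this is the first single-place step available. In this pair, the amide hydrogen and the hydrogen-bond acceptors of the leaving group are gone and a six-membered non-aromatic ring has entered, yet the two values remain within the scatter of each other, so the value at this position does not depend on keeping that open chain, at least on the cyclohexyl-bearing background of compound 1. Nothing measured in the series speaks to why the two values stay this close.

This one pair cannot separate the loss of the amide hydrogen from the loss of the methoxycarbonyl group or from the entry of the ring. The compounds shown also leave open how this position responds to a carboxylic acid at the end of the chain, a longer chain, an unsubstituted piperidin-1-yl or a morpholin-4-yl group.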